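The source may report more compounds than this note shows. Statements on the series, on what has been measured and on what is new or still open speak of the compounds shown alone.

Measured so far in a physicochemical assay for acid dissociation:
compound 1 `NS(=O)(=O)c1ccc(S(=O)(=O)CCCO)cc1` gives 8.98
compound 2 `NS(=O)(=O)c1ccc(S(=O)(=O)CC(O)CO)cc1` gives 9.35
compound 3 `NS(=O)(=O)c1ccc(SCCCCO)c(F)c1` gives 9.82

Of these three, compound 1 has the lowest number. Compound 2 lies nearest to it and compound 3 lies furthest above it. The next compound to be measured is compound 4 `NS(=O)(=O)c1ccc(S(=O)(=O)CCCO)c([N+](=O)[O-])c1`, which keeps the core of compound 1 and makes one change: nitro in place of hydrogen on an aromatic carbon. Going by the values given here, only one measured step starts from compound 1, and it is a number 0.37 log units higher from compound 1 to compound 2 (beyond the scatter) in this series. That step is hydroxy in place of hydrogen on a saturated chain carbon, so it concerns the chain and gives no direct guide to a change on an aromatic carbon. Compound 3 differs from compound 1 in more than one place and cannot isolate such a change either. Among the compounds with values here, the data hold no measured step for nitro, and the expectation therefore rests on the structural change alone and carries a wide range. A move to a lower number in this assay is expected here, larger than the chain step and beyond the scatter. The expected change is a number 0.78 log units lower from compound 1 to compound 4 (beyond the scatter) by this estimate. Compound 4 is estimated at 8.2 with an expected range from 7.8 to 8.6 until it is measured.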

Compound 4, acid dissociation constant: 8
For compound 4 the middle estimate is 0.20 log units above the measured one, within the range that was stated.
By their numbers in this assay, from the lowest: compound 4; then compound 1; then compound 2; then compound 3.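

In this assay, going by these compounds alone, nitro in place of hydrogen on an aromatic carbon, ortho to a group of 7 heavy atoms and meta to a sulfamoyl group, gives the only single change on the aromatic ring that can be read on its own here, with a number 0.98 log units lower from compound 1 to compound 4 (beyond the scatter). Within the data shown here, the only earlier single-change step lay on the saturated chain and ran the opposite way, with a number 0.37 log units higher from compound 1 to compound 2 (beyond the scatter), so the series now shows that the number can be moved in both directions from compound 1, downward through this aromatic carbon and upward through the chain. Nothing available explains why this aromatic change lowers the number, and the size of the step therefore stands as an observation without a stated cause.

From the compounds shown here alone, it remains open whether another group on this same aromatic carbon, such as an amine, a carboxylic acid or trifluoromethyl, would shift the number in the same direction as nitro, and by how much. Going by these compounds, it is also open whether nitro would give a step of similar size on the chain of compound 2, or on a different aromatic carbon of the shared core.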